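The compounds below may be only part of what the source reports. "The series", "measured", "known", "first", "only" and "open" are said of these compounds alone.

Measured compounds:
compound 1 `CC(C)CCn1ccc(-c2ccc(Oc3ccccc3)cc2)c(C#N)c1=O`: 188%
compound 2 `CC(C)CCn1ccc(-c2ccc(Oc3ccccn3)cc2)c(C#N)c1=O`: 249%
compound 3 `Cc1cc(Oc2ccc(-c3ccn(CCC(C)C)c(=O)c3C#N)cc2)ccn1`: 266%

In a functional assay on CHO cells for positive allosteric modulation of metabotropic glutamate receptor 2 (Homo sapiens), read by scintillation counting and GTPgammaS binding, with a stated time of 30 min (a lower number here means a smaller maximal response, a higher number a larger maximal response), compound 3 gives 266%, the highest of the three numbers. Compound 2 stands nearest, with a number 17 percentage points higher from compound 2 to compound 3 (beyond the scatter); compound 1 stands furthest, with a number 78 percentage points higher from compound 1 to compound 3 (beyond the scatter).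

Compound 4 `Cc1ccc(Oc2ccc(-c3ccn(CCC(C)C)c(=O)c3C#N)cc2)c(C)n1` differs from compound 3 in one place: 2,6-dimethylpyridin-3-yl in place of 2-methylpyridin-4-yl on an oxygen on an aromatic ring.

The measured steps that bear on this are the two aryl-to-pyridyl exchanges on the oxygen, a number 61 percentage points higher from compound 1 to compound 2 (beyond the scatter) and a number 78 percentage points higher from compound 1 to compound 3 (beyond the scatter), both large, and the pyridyl-to-pyridyl exchange a number 17 percentage points higher from compound 2 to compound 3 (beyond the scatter), which was modest. Among the measured compounds shown here, the change to compound 4 is of the second kind, one pyridyl for another on the oxygen, so a step of the modest kind is the reasonable expectation, while its direction is not fixed by anything measured, since no compound carries 2,6-dimethylpyridin-3-yl. Compound 4 is therefore expected to give about 250% in this assay, in the range 200% to 300%. The step of a number 16 percentage points lower from compound 3 to compound 4 (beyond the scatter) implied by this estimate is expected to be small, possibly not beyond the scatter.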

Compound 4, largest response reached (Emax), in percent of the reference or control that the assay uses: 246%
Compound 4: middle estimate off by 4 percentage points, on the high side, within the range that was stated.
By their numbers in this assay, from the lowest: compound 1; then compounds 4 and 2 (each within the scatter of the next); then compound 3.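

In this assay, 2,6-dimethylpyridin-3-yl in place of phenyl on the oxygen gives a number 58 percentage points higher from compound 1 to compound 4 (beyond the scatter) and so keeps a large gain, which makes three different pyridyl groups that all stand clear of the phenyl compound. The same group gives a number 20 percentage points lower from compound 3 to compound 4 (beyond the scatter) against 2-methylpyridin-4-yl, while a number 3 percentage points lower from compound 2 to compound 4 (within the scatter) leaves it level with pyridin-2-yl, so the added methyl of compound 4 brings no gain over the best pyridyl group shown. Nothing measured accounts for these differences.

The change to compound 4 alters both the number of methyl groups and the ring's point of attachment to the oxygen, and the compounds shown do not separate the two. Also open, as far as these compounds go, is how a pyrimidine ring, or a methoxy or aminomethyl group on the pyridine, would read in this assay at this position.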